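Methyl to ethyl ester trimming in an alkynyl ester series

This account rests on a few compounds, and the source may have more. Where it says the series, first, only, none or still open, it means among the compounds named here.

Of the compounds shown here, three have been tested in a functional assay on HBL-100 cells (Homo sapiens) for antiproliferative activity, read by sulforhodamine B assay, with a stated time of 48 h; on this read-out lower numbers stand for stronger inhibition of growth and higher numbers for weaker inhibition of growth. Compound 1 `CCOC(=O)C#CC(O/C=C/C(=O)OCC)C(C)C` gives 3000 nM. Compound 2 `CCCCCC(C#CC(=O)OC)O/C=C/C(=O)OC` gives 1900 nM, and compound 3 `CCCCCCC(C#CC(=O)OC)O/C=C/C(=O)OC` gives 2500 nM. Compound 3 and compound 2 are joined by one change, (hydrogen in place of methyl on a saturated chain carbon, six bonds along the chain from an oxygen on an unsaturated carbon and a triple-bonded carbon), and the step of a 1.3-fold lower number from compound 3 to compound 2 (0.12 log units; within the scatter). Compound 4 `CCOC(=O)C#CC(O/C=C/C(=O)OC)C(C)C` has not been measured; it differs from compound 1 by hydrogen in place of methyl on a saturated chain carbon bound to an oxygen next to a carbonyl group. This is the same kind of change as that from compound 3 to compound 2, but the place differs: in compound 1 the saturated chain carbon is bound to an oxygen next to a carbonyl group, whereas in compound 3 it sits six bonds along the chain from an oxygen on an unsaturated carbon and a triple-bonded carbon. How the core of compound 1 differs from that of compound 3 is not broken down here. Resting on the step of a 1.3-fold lower number from compound 3 to compound 2 (0.12 log units; within the scatter) from compound 3 to compound 2, the step of a 1.1-fold lower number from compound 1 to compound 4 (0.03 log units; within the scatter) is expected to be small. Compound 4 is thus estimated at 2800 nM, expected to fall between 1500 nM and 5500 nM.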

Compound 4, concentration for 50% growth inhibition: 880 nM
Compound 4: middle estimate off by 3.2-fold (0.50 log units), on the high side; measured number outside the range, below it.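

Cutting ethoxycarbonyl to methoxycarbonyl on the core of compound 1 gives, in this assay, a 3.4-fold lower number from compound 1 to compound 4 (0.53 log units; beyond the scatter), so this change does register on that core. Set beside the hydrogen-for-methyl change on the other core, the two steps cannot be told apart: the same change on two cores in this assay, a 1.3-fold lower number (0.12 log units; within the scatter) from compound 3 to compound 2 and a 3.4-fold lower number (0.53 log units; beyond the scatter) from compound 1 to compound 4, 2.6-fold (0.41 log units) apart, within the scatter of two such steps. This does not show that the change carries over with the same size, since the two steps sit at different places on different cores and each rests on a single pair.

The compounds shown leave open whether changing the remaining ethoxycarbonyl of compound 4 to methoxycarbonyl would move the number further. They also leave open how a carboxylic acid or an amide would read in place of the ester.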